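Swapping an oxadiazole for a carbamate on the piperazine

This account rests on a few compounds, and the source may have more. Where it says the series, first, only, none or still open, it means among the compounds named here.

Compound 1 `CCOC(=O)[C@H]1CCN(S(=O)(=O)c2ccc(S(=O)(=O)N(CC)CC)cc2)C1`: in a functional assay on MIA PaCa-2 cells (Homo sapiens) for inhibition, read by MTT assay, with a stated time of 3 days (a higher number here means a weaker inhibitor, a lower number a stronger inhibitor), compound 1 gives > 10000 nM, a limit of the assay.
Compound 2 `CCN(CC)S(=O)(=O)c1ccc(S(=O)(=O)N2CCC[C@@H](C(=O)N3CCN(c4nc(C)no4)CC3)C2)cc1`: in this assay compound 2 gives > 10000 nM, again a limit.
Compound 3 `CCN(CC)S(=O)(=O)c1ccc(S(=O)(=O)N2CCC[C@@H](C(=O)N3CCN(c4nnc(C(C)C)o4)CC3)C2)cc1`: in this assay compound 3 gives > 10000 nM, also a limit.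

Compound 3 therefore stands at the edge of what this assay can report, as do the other two compounds, and this is summarised in the limit of > 10000 nM in this assay, at which 3 of the 3 values shown sit. Among the compounds with values here, the only single-point step among them, a step that the two limits leave unreadable from compound 2 to compound 3, cannot be read for size because both ends are limits.

Compound 4 `CCN(CC)S(=O)(=O)c1ccc(S(=O)(=O)N2CCC[C@@H](C(=O)N3CCN(C(=O)OC(C)(C)C)CC3)C2)cc1` differs from compound 3 in one place: tert-butoxycarbonyl in place of 5-isopropyl-1,3,4-oxadiazol-2-yl on an amine nitrogen in a ring. Within the data shown here, no measured step covers a change of this kind, and the one step that touches the same ring nitrogen is unreadable, so it offers no direction to expect. The expectation for compound 4 rests only on the fact that all three neighbours sit at the limit, and the expected step that the limit leaves unreadable from compound 3 to compound 4 is therefore none beyond the scatter. Compound 4 is estimated to give 20000 nM in this assay, within 8000 nM to 60000 nM, most likely reported as a limit again.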

Compound 4, half-maximal inhibitory concentration: > 10000 nM
Compound 4: only a limit was reported; the forecaster's own chance of this, stated with the estimate: 85%; the middle value is on the limit's open side.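

Compound 4 also returns only a limit in this assay, so the steps to it from compound 2 and from compound 3 cannot be read for size. All the results shown stand at one edge: the limit of > 10000 nM in this assay, at which 4 of the 4 values shown sit. The compounds shown leave open whether any group on this ring nitrogen changes inhibition at all.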